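Methyl added to the N-phenyl of compound 1

The source may hold more compounds than are shown below. What is called first, only, known or untested is meant among the compounds shown, and "the series" means these compounds.

Measured so far:
- compound 1 `COc1ccc(-n2sc(=O)n(-c3ccccc3)c2=O)cc1`: < 2000 nM in an ADME assay, in phosphate buffer, with a stated time of 30 min, tested at 1 mM, at a dose of 1 mM; on this read-out lower numbers stand for lower exposure and higher numbers for higher exposure at the dose given.
- compound 2 `COc1ccc(-n2sc(=O)n(C3CCCCC3)c2=O)cc1`: < 2000 nM.
- compound 3 `O=c1sn(-c2ccccc2)c(=O)n1Cc1ccccc1`: 2380 nM.

Compound 1 shows a value that is a limit of this assay, not a number. For compound 2 the value shown is likewise a limit. Compound 3 gives a number, 2380 nM, the only one in the set. Within the data shown here, the one step between compounds that differ in a single place, a step that the two limits leave unreadable from compound 1 to compound 2, cannot be read because of the limit of < 2000 nM in this assay, at which 2 of the 3 values shown sit. Compound 1 therefore stands only as a limit, with one further value in the set also a limit.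

Compound 4 `COc1ccc(-n2sc(=O)n(-c3ccc(C)cc3)c2=O)cc1` is not yet measured in this assay. It differs from compound 1 by methyl in place of hydrogen on an aromatic carbon, on an aromatic carbon of a six-membered aromatic ring of carbon only, para to a large group. Among the measured compounds shown here, no measured step touches this position or this group, so nothing in the set gives a size or a direction for the change; the expectation is a step no larger than the scatter, and a fair chance that this assay again returns only a limit.

The step that the limit leaves unreadable from compound 1 to compound 4 is the expected outcome. Compound 4 is expected to give about 1500 nM, with a range from 500 nM to 3500 nM.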

Compound 4, maximal plasma concentration: < 2000 nM
Compound 4 ended at the assay's limit; the forecaster's own chance of this, stated with the estimate: 60%; the middle value does not contradict the limit.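

Compound 4, like compound 1 and compound 2, returns only a limit in this assay, so no step among these three compounds can be read: the limit of < 2000 nM in this assay, at which 3 of the 4 values shown sit.

The compounds shown leave open whether methyl in place of hydrogen on the aromatic carbon changes the maximal plasma concentration at all, and in which direction.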